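This account rests on a few compounds, and the source may have more. Where it says the series, first, only, none or still open, it means among the compounds named here.

Three compounds share one core, an ethyl ester on one ring joined to a second ring that carries a group opposite to it. Compound 1 `CCOC(=O)c1cccc(-c2ccc(OCC)cc2)c1` carries ethoxy there, and in an assay on COS-7 cells for inhibition of patatin-like phospholipase domain-containing protein 2 (Mus musculus) (on this read-out higher numbers stand for weaker inhibition and lower numbers for stronger inhibition), compound 1 gives 50000 nM. Compound 2 `CCOC(=O)c1cccc(-c2ccc(O)cc2)c1` carries a free hydroxyl, and in this assay compound 2 gives 100000 nM. Compound 3 `CCOC(=O)c1cccc(-c2ccc(OC)cc2)c1` carries methoxy, and in this assay compound 3 gives 80000 nM. All three numbers lie within the usual scatter of one another: a 2.0-fold higher number from compound 1 to compound 2 (0.30 log units; within the scatter), a 1.6-fold higher number from compound 1 to compound 3 (0.20 log units; within the scatter), and a 1.3-fold lower number from compound 2 to compound 3 (0.10 log units; within the scatter). Compound 3 thus sits among three indistinguishable numbers, with compound 2 nearest and compound 1 furthest.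

Compound 4 `CCOC(=O)c1cccc(-c2ccc(N(C)C)cc2)c1` differs from compound 3 by dimethylamino in place of methoxy on an aromatic carbon. Going by the values given here, none of the measured steps bears directly on this exchange, since each of them only alters what hangs on the oxygen, whereas here the oxygen itself gives way to nitrogen. Among the compounds with values here, the only guidance is that three variations at this position left the numbers in this assay unchanged beyond the scatter, so the expectation for the step from compound 3 to compound 4 is a 1.1-fold lower number from compound 3 to compound 4 (0.06 log units; within the scatter), that is, no shift beyond the scatter. Compound 4 is therefore estimated at 70000 nM, with a range from 30000 nM to 160000 nM.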

Compound 4, half-maximal inhibitory concentration: 40000 nM
Compound 4: the middle estimate sits 1.8-fold (0.24 log units) above what was measured, within the range that was stated.
By their numbers in this assay, from the lowest: compounds 4, 1, 3 and 2 (each within the scatter of the next, the first and the last beyond it).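

In this assay, going by these compounds alone, dimethylamino is the first group at this position to produce a step beyond the scatter, and it does so only against the free hydroxyl, with a 2.5-fold lower number from compound 2 to compound 4 (0.40 log units; beyond the scatter) being a modest shift. Against the two groups that keep an oxygen on the ring and carry a carbon chain on it, the exchange cannot be told apart from the scatter: methoxy gives a 2.0-fold lower number from compound 3 to compound 4 (0.30 log units; within the scatter) and ethoxy gives a 1.3-fold lower number from compound 1 to compound 4 (0.10 log units; within the scatter) as its counterpart, so nitrogen can take the place of oxygen on this aromatic carbon without a clear separation from either of these two compounds. Within the data shown here, nothing measured alongside these numbers accounts for the single step that stands out.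

With dimethylamino as the only nitrogen group here, the compounds shown leave open whether a primary amine, an amide or a longer chain on the nitrogen would carry the number further from that of the free hydroxyl or back towards it. They also leave open whether the same order of groups would hold if a carboxylic acid stood in place of the ethyl ester on the shared core.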